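Phenyl for Cyclopentyl at the Ring Amine

This account rests on a few compounds, and the source may have more. Where it says the series, first, only, none or still open, it means among the compounds named here.

Among the measured compounds shown here, compound 1 `O=C(/C=C/C=C/c1ccccc1[N+](=O)[O-])N1CCN(C2CCCC2)CC1` gives 69.2 nM in a functional assay on CHO cells (Cricetulus griseus) for inhibition, read by FLIPR and calcium flux, with a stated time of 48 h (on this read-out higher numbers stand for weaker binding and lower numbers for tighter binding), the lower of the two numbers measured so far. Compound 2 `O=C(/C=C/c1ccccc1[N+](=O)[O-])N1CCN(CC2CCCCC2)CC1` gives 490 nM in this assay, a higher number beyond the scatter, though the two structures differ in more than one place. Compound 3 `O=C(/C=C/C=C/c1ccccc1[N+](=O)[O-])N1CCN(c2ccccc2)CC1` has not been measured; it differs from compound 1 by phenyl in place of cyclopentyl on an amine nitrogen in a ring. For the measured compounds named here, no measured pair shows this change on its own, so its size is open. Compound 3 is expected to give 150 nM in this assay, within 40 nM to 600 nM. The step of a 2.2-fold higher number from compound 1 to compound 3 (0.34 log units; beyond the scatter) is expected to be modest, toward a higher number, near the edge of the scatter.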

Compound 3, dissociation constant: 58.9 nM
Estimate against measurement, compound 3: 2.5-fold (0.41 log units) above; measured number inside the range.
By their numbers in this assay, from the lowest: compounds 3 and 1 (each within the scatter of the next); then compound 2.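

Among the compounds shown here, the step of a 1.2-fold lower number from compound 1 to compound 3 (0.07 log units; within the scatter) is the first direct reading of this change in this assay: with phenyl or cyclopentyl on the amine nitrogen in a ring, the two compounds lie within the scatter of each other. At this position, then, a six-membered aromatic ring of carbon and a five-membered non-aromatic ring of carbon give matching numbers. Nothing among the data shown accounts for this result. As far as these compounds go, whether a pyridine ring, a methyl group or an aminoalkyl chain on the same nitrogen would give a matching number remains open.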